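A few compounds are considered here, and "the series" means these few. Any claim that something is new, unique, unknown or untested is made for them only; others in the source may bear on it.

Working notes on the series. Within the data shown here, compound 1 `CCc1ccc(NC(=O)Nc2cc(C)nc3ccccc23)cc1` is the only compound of the set with a number in an ADME assay on HepG2 cells (Homo sapiens) for cytotoxicity, with a stated time of 72 h; a higher number here means that more compound is needed for the effect, a lower number that less compound is needed: compound 1 gives 17000 nM. Compound 2 `Cc1cc(NC(=O)Nc2cc(F)cc(F)c2)c2ccccc2n1` sits at a limit of this assay, and for compound 2 the read-out is > 25000 nM, a limit of the measurement rather than a number (the limit of > 25000 nM in this assay, at which 1 of the 2 values shown sits). Compound 3 `Cc1cc(NC(=O)Nc2ccc(C(=O)O)cc2)c2ccccc2n1` is unmeasured; it differs from compound 1 by carboxy in place of ethyl on an aromatic carbon. The step from compound 1 to compound 3 in this assay is expected to be small to modest, toward a higher half-maximal effective concentration, as a 1.8-fold higher number from compound 1 to compound 3 (0.25 log units; within the scatter). Compound 3 is estimated at 30000 nM, between 12000 nM and 80000 nM.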

Compound 3, half-maximal effective concentration: > 25000 nM
Compound 3 gave a limit, no number; the forecaster's own chance of this, stated with the estimate: 60%; the middle value does not contradict the limit.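

Among these compounds, the exchange on this aromatic carbon, para to a large group, gives the first readable step in this assay: an at least 1.4-fold higher number from compound 1 to compound 3 (0.16 log units; that floor lies within the scatter). On these data alone, only a floor is available for this step, so its true size remains unknown, and carboxy in place of ethyl shows no move toward a lower number. Compound 3 therefore joins the compounds at the limit: the limit of > 25000 nM in this assay, at which 2 of the 3 values shown sit.

As far as these compounds go, it remains open how far past the limit compound 3 lies. From the compounds shown here alone, how an amine or a longer chain at this position would read in this assay also remains open.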